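The source may report more compounds than this note shows. Statements on the series, on what has been measured and on what is new or still open speak of the compounds shown alone.

Measured compounds in the series:
- compound 1 `O=C(NC1CCN(Cc2ccn(-c3ccc(C(F)(F)F)cc3)c2)CC1)N1CCC(c2ccccc2O)CC1`: 36 nM
- compound 2 `O=C(NC1CCN(Cc2ccn(-c3ccc(C(F)(F)F)cc3)c2)CC1)N1CCCC1Cc1cccnc1`: 26 nM
- compound 3 `O=C(NC1CCN(Cc2ccn(-c3ccc(C(F)(F)F)cc3)c2)CC1)N1CCCC(CO)C1`: 23 nM

In an assay on HEK293 cells for displacement of a labelled ligand from melanin-concentrating hormone receptor 1 (Homo sapiens) (on this read-out lower numbers stand for stronger inhibition and higher numbers for weaker inhibition), compound 3 gives 23 nM, the lowest of the three numbers recorded so far. The nearest is compound 2, and the furthest is compound 1; both gaps lie within the scatter, so the three compounds cannot be ranked against each other. Within the data shown here, the only one-place step measured is a 1.1-fold lower number from compound 2 to compound 3 (0.05 log units; within the scatter), a swap of one ring amine for another on the carbonyl carbon that left the read-out unchanged within the scatter.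

Compound 4 `O=C(O)CC(NC(=O)NC1CCN(Cc2ccn(-c3ccc(C(F)(F)F)cc3)c2)CC1)c1ccccc1` is the next candidate. The change from compound 3 is (2-carboxy-1-phenylethyl)amino in place of 3-(hydroxymethyl)piperidin-1-yl on a carbonyl carbon. Among the measured compounds shown here, no measured step covers an exchange of a cyclic amine for an acyclic amino group carrying a carboxylic acid and a phenyl ring; the one step in hand, from compound 2 to compound 3, shows only that two different ring amines at this position gave the same number. The expectation is therefore weakly founded: a modest loss seems somewhat more likely than a gain, but a result within the scatter of compound 3 cannot be excluded. The step from compound 3 to compound 4 is estimated as a 3.5-fold higher number from compound 3 to compound 4 (0.54 log units; beyond the scatter). For compound 4 the estimated value in this assay is 80 nM, with a range from 20 nM to 400 nM.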

Compound 4, half-maximal inhibitory concentration: 412 nM
Compound 4: the middle estimate sits 5.2-fold (0.71 log units) below what was measured; measured number outside the range, above it.
By their numbers in this assay, from the lowest: compounds 3, 2 and 1 (each within the scatter of the next); then compound 4.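

In this assay, the (2-carboxy-1-phenylethyl)amino group on the carbonyl carbon gives an 18-fold higher number from compound 3 to compound 4 (1.25 log units; beyond the scatter) and a 16-fold higher number from compound 2 to compound 4 (1.20 log units; beyond the scatter) for the same exchange made from the other ring amine. This position is therefore not indifferent to what it carries: the earlier step between the two ring amines stayed within the scatter, whereas both of these steps are large and beyond it. No measured evidence here accounts for the loss, and the entering group replaces the ring amine, adds a carboxylic acid and adds a phenyl ring all in one exchange, so the step cannot be assigned to any one of these.

The compounds shown leave open whether the carboxylic acid, the open-chain amino link or the phenyl ring carries the step, and a methyl ester or primary amide in place of the carboxylic acid on the same (2-carboxy-1-phenylethyl)amino frame would separate the first of these from the rest. They also leave open whether a carboxylic acid carried on a piperidine ring, as the hydroxymethyl group of compound 3 is, would give a number near that of compound 3 or near that of compound 4.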